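Benzyl to phenyl on the sulfonamide nitrogen

The source may hold more compounds than are shown below. What is called first, only, known or untested is meant among the compounds shown, and "the series" means these compounds.

Compound 1 `CN(c1ccccc1)S(=O)(=O)c1ccc(NC(=O)c2ccc(Cl)cc2Cl)cc1` gives 2570 nM in a functional assay on HEK293 cells for agonist activity at probable G-protein coupled receptor 27 (Homo sapiens), read by a luciferase reporter and beta-arrestin recruitment, with a stated time of 10 min; a higher number here means that more compound is needed for the effect, a lower number that less compound is needed. Compound 3 `O=C(Nc1ccc(S(=O)(=O)Nc2ccccc2)cc1)c1ccc(I)cc1F`, which carries an anilino group on its sulfonamide nitrogen, gives 5130 nM in this assay. For compound 2 `O=C(Nc1ccc(S(=O)(=O)NCc2ccccc2)cc1)c1ccc(Cl)cc1Cl` the reading in this assay is only a limit, > 100000 nM, and no number is known for it. Compound 2 therefore stands at the weak end of the values shown, sitting at the limit of > 100000 nM in this assay, at which 1 of the 3 values shown sits. The unmeasured compound 4 `O=C(Nc1ccc(S(=O)(=O)Nc2ccccc2)cc1)c1ccc(Cl)cc1Cl` differs from compound 2 by phenyl in place of benzyl on a sulfonamide nitrogen. Within the data shown here, the one measured step that touches this sulfonamide nitrogen is an at least 38-fold higher number from compound 1 to compound 2 (1.59 log units; beyond the scatter), a large rise in the required concentration when benzylamino replaced methyl(phenyl)amino. Moving back to an anilino group, as in compound 3, is expected to reverse much of that, so a large step toward a lower number is expected in this assay, estimated as an at least 25-fold lower number from compound 2 to compound 4 (1.39 log units; beyond the scatter). Compound 4 is accordingly expected to give about 4000 nM in this assay, within the range 1200 nM to 20000 nM.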

Compound 4, half-maximal effective concentration: 457 nM
Compound 4: the middle estimate sits 8.8-fold (0.94 log units) above what was measured; measured number outside the range, below it.
By their numbers in this assay, from the lowest: compound 4; then compounds 1 and 3 (each within the scatter of the next). At a limit, above all of these: compound 2.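

In this assay, phenyl in place of benzyl on a sulfonamide nitrogen gives an at least 210-fold lower number from compound 2 to compound 4 (2.34 log units; beyond the scatter), so this position separates the two groups sharply when the nitrogen also carries hydrogen. The reading for compound 2 is a limit and not a number, so this step is only a bound: the limit of > 100000 nM in this assay, at which 1 of the 4 values shown sits. With phenyl kept on that nitrogen, hydrogen in place of methyl gives a 5.6-fold lower number from compound 1 to compound 4 (0.75 log units; beyond the scatter), while 2,4-dichlorophenyl in place of 2-fluoro-4-iodophenyl on a carbonyl carbon gives an 11-fold lower number from compound 3 to compound 4 (1.05 log units; beyond the scatter), so the number also depends on the group at the carbonyl carbon.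

On these data alone, whether a longer chain such as 2-phenylethyl or a pyridyl ring on the sulfonamide nitrogen would keep the number low remains open. Also open is which halogen in the 2,4-dichlorophenyl or 2-fluoro-4-iodophenyl group accounts for the step at the carbonyl carbon.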